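A few compounds are considered here, and "the series" means these few. Any claim that something is new, unique, unknown or untested is made for them only; others in the source may bear on it.

In an assay on isolated protein for binding affinity to corticotropin-releasing factor receptor 1 (Homo sapiens) (on this read-out lower numbers stand for stronger inhibition and higher numbers for weaker inhibition), the measured compounds stand as follows:

Compound 1, `CCN(c1nc(C)cc(C)n1)c1c(Br)cc(OC)cc1OC`: 12 nM
Compound 2, `CCN(CC)c1cc(C)nc(N(CC)c2c(Br)cc(OC)cc2OC)n1`: 48 nM
Compound 3, `CCN(CC)c1cc(C)nc(N(CC)c2c(Br)cc(C(C)C)cc2SC)n1`: 26 nM

Compounds 1 and 2 share a core and differ in one place, (methyl in place of diethylamino on an aromatic carbon). On this assay the step is a 4.0-fold lower number from compound 2 to compound 1 (0.60 log units; beyond the scatter), a modest gain for the smaller group.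

Compound 3 carries a different substitution on the core than compound 2; the difference between the two cores is not broken down here. What the two values show is that compound 3 and compound 2 lie within the scatter of each other, while compound 1 sits lower than compound 3 by a margin beyond the scatter.

Compound 4, `CCN(c1nc(C)cc(C)n1)c1c(Br)cc(C(C)C)cc1SC`, is not yet measured. It stands to compound 3 as compound 1 stands to compound 2: the change is methyl in place of diethylamino on an aromatic carbon, and the surroundings of the place are the same word for word in both pairs, so this is the same change made on the core of compound 3.

Within the data shown here, on this assay a step of a 4.0-fold lower number from compound 3 to compound 4 (0.60 log units; beyond the scatter) is expected, resting on the single earlier instance of the change, a 4.0-fold lower number from compound 2 to compound 1 (0.60 log units; beyond the scatter), carried over from compound 3. Among the measured compounds shown here, with only one precedent and a different core, the estimate is held loosely. For compound 4 the expected value is 6.5 nM, estimated to fall between 2.5 nM and 17 nM.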

Compound 4, inhibition constant: 51 nM
Estimate against measurement, compound 4: 7.8-fold (0.89 log units) below, and the stated range ends below it.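

In this assay, methyl in place of diethylamino on an aromatic carbon does not give the same result on the core of compound 3 as on the core of compound 2: the step here is a 2.0-fold higher number from compound 3 to compound 4 (0.29 log units; within the scatter), so the gain seen on the first core does not reappear, and the two compounds on this core cannot be told apart on this read-out. Set side by side, the two instances disagree by more than repeated measurement would explain, and the outcome of this change depends on the core it is made on: the same change on two cores in this assay, a 4.0-fold lower number (0.60 log units; beyond the scatter) from compound 2 to compound 1 and a 2.0-fold higher number (0.29 log units; within the scatter) from compound 3 to compound 4, 7.8-fold (0.89 log units) apart, beyond the scatter of two such steps. Among these compounds, with one pair on each core, this shows only that the step does not transfer from the core of compound 2 to the core of compound 3; it does not show which difference in the cores is responsible, how the change would behave on any third core, or that either step is typical of the series.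

From the compounds shown here alone, the two cores differ in more than one place, so it stays open whether the methoxy groups or the isopropyl and methylthio groups decide the outcome when they are exchanged one at a time. Also open, going by these compounds, is how a dimethylamino group, a cyclic amine such as morpholine or a longer chain such as propyl would behave in the place of diethylamino on each core.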